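Swapping isopropyl for fluoro on a phenylurea

The source may hold more compounds than are shown below. What is called first, only, known or untested is meant among the compounds shown, and "the series" means these compounds.

The measured compounds and their values:
compound 1 `CCc1ccccc1NC(=O)N[C@H](C)c1ccccc1`: 92%
compound 2 `CC(C)c1cccc(NC(=O)N[C@H](C)c2ccccc2)c1`: 44%
compound 3 `CC(C)c1cccc(NC(=O)N[C@@H](C)c2ccccc2)c1`: 86%

In an ADME assay on the whole organism with Oryza sativa as the target, tested at 10 uM (a lower number here means a stronger effect, a higher number a weaker effect of the compound at the concentration tested), compound 3 stands second highest of the three, close to compound 1, which gives 92%, within the scatter of it, and far from compound 2, which gives 44%. Among the compounds with values here, the one step that is resolved is a number 42 percentage points higher from compound 2 to compound 3 (beyond the scatter), and its origin lies in the fact that compounds 2 and 3 differ only in the configuration as drawn: the two share every atom and bond and differ only in how the saturated chain carbon is drawn.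

Compound 4 `C[C@H](NC(=O)Nc1cccc(F)c1)c1ccccc1` is not yet measured. It differs from compound 3 by fluoro in place of isopropyl on an aromatic carbon. Within the data shown here, no measured step touches this kind of change; the only resolved step concerns configuration alone, and the difference between compound 1 and compound 3 lies within the scatter. Nothing in the numbers therefore points to a move beyond the scatter. In this assay compound 4 is expected to give 88%, with a range from 72% to 100%, which is estimated to mean a step of a number 2 percentage points higher from compound 3 to compound 4 (within the scatter).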

Compound 4, a percentage reported as activity, at one concentration (the size of the read-out at that concentration, not a potency): 88%
Compound 4: middle estimate and measured number agree at the digits printed; the measured number falls inside the stated range.
By their numbers in this assay, from the lowest: compound 2; then compounds 3, 4 and 1 (each within the scatter of the next).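

At the aromatic carbon meta to a large group, fluoro, with 1 heavy atom, in place of isopropyl, with 3 heavy atoms, gives a number 2 percentage points higher from compound 3 to compound 4 (within the scatter) in this assay. Within the data shown here, the earlier compounds resolved only a change of drawn configuration, and this is the first view of a change of substituent at this place: with the configuration unchanged, the group can go from isopropyl to fluoro without the read-out moving beyond the scatter. Nothing at hand speaks to why the read-out holds across this change.

On these data alone, it remains open whether the configuration drawn in compound 2, which gives 44% with isopropyl, would also set a fluoro compound apart from compound 4 in this assay, or whether that gap belongs to the isopropyl compounds alone. Also open, as far as these compounds go, is whether any group at this place can move the read-out beyond the scatter of compound 3, for example an amine, a carboxylic acid or a methoxy group.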